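Benzyl thioether in place of the ester chain

The source may hold more compounds than are shown below. What is called first, only, known or untested is meant among the compounds shown, and "the series" means these compounds.

Among the measured compounds shown here, compound 2 `CCOC(=O)CCCSc1nc2ccccc2n1CC(=O)O` gives 4410 nM in an assay on HEK293 cells for displacement of a labelled ligand from prostaglandin D2 receptor 2 (Homo sapiens) (on this read-out higher numbers stand for weaker inhibition and lower numbers for stronger inhibition), the higher of the two numbers measured so far; compound 1 `O=C(O)Cn1c(SCCCOc2ccccc2)nc2ccccc21` gives 786 nM. For the measured compounds named here, the only measured step runs a 5.6-fold higher number from compound 1 to compound 2 (0.75 log units; beyond the scatter). Compound 3 `O=C(O)Cn1c(SCc2cccc(Br)c2)nc2ccccc21` differs from compound 2 by 3-bromophenyl in place of 2-(ethoxycarbonyl)ethyl on a saturated chain carbon bound to a sulfur. The change removes the ethoxycarbonyl end that went with the weaker number and brings in a six-membered aromatic ring, as compound 1 carries, so a lower number is expected, of a size near that single step. For compound 3 the estimated value in this assay is 800 nM, range 250 nM to 2500 nM, an expected step of a 5.5-fold lower number from compound 2 to compound 3 (0.74 log units; beyond the scatter).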

Compound 3, half-maximal inhibitory concentration: 370 nM
Estimate against measurement, compound 3: 2.2-fold (0.33 log units) above; the measured number falls inside the stated range.
By their numbers in this assay, from the lowest: compound 3; then compound 1; then compound 2.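

On the saturated chain carbon bound to a sulfur, 3-bromophenyl in place of 2-(ethoxycarbonyl)ethyl gives a 12-fold lower number from compound 2 to compound 3 (1.08 log units; beyond the scatter) in this assay, a large step. Compound 2, with its ethoxycarbonyl end, now holds the higher number in both measured steps, and this position accepts a six-membered aromatic ring carried on that chain carbon. Nothing available explains the size of this step.

Open, going by these compounds, is whether a plain phenyl or a pyridine ring in place of 3-bromophenyl would hold the number. Also open, on these data alone, is how a carboxylic acid in place of the ethyl ester end of compound 2 would read.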